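This account rests on a few compounds, and the source may have more. Where it says the series, first, only, none or still open, it means among the compounds named here.

In an ADME assay on WI-38 cells (Homo sapiens) for antiproliferative activity, read by sulforhodamine B assay, with a stated time of 72 h (on this read-out lower numbers stand for stronger inhibition and higher numbers for weaker inhibition), compound 1 `CCCSc1ccc2c3c(cccc13)C1=NC(=O)C(C(=O)OCC)=C12` gives 9600 nM, while compound 2 `C=CCOC(=O)C1=C2C(=NC1=O)c1cccc3c(SCC=C)ccc2c13` gives 19700 nM, the higher of the two numbers and so the weaker inhibition. Compound 3 `C=CCSc1ccc2c3c(cccc13)C1=NC(=O)C(C(=O)OCC)=C12` has not yet been measured. It differs from compound 2 in one place: methyl in place of vinyl on a saturated chain carbon bound to an oxygen next to a carbonyl group, with methyl in place of vinyl on a saturated chain carbon bound to an oxygen next to a carbonyl group, turning allyloxycarbonyl into ethoxycarbonyl. In this assay a small step towards a lower number is expected, close to the scatter, since compound 1 also carries ethoxycarbonyl and gives 9600 nM. The estimate means an expected step of a 1.6-fold lower number from compound 2 to compound 3 (0.22 log units; within the scatter). For compound 3 the estimated value is 12000 nM, with a range from 6000 nM to 22000 nM.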

Compound 3, half-maximal inhibitory concentration: 4600 nM
The estimate for compound 3 lay 2.6-fold (0.42 log units) above the measured number; the whole stated range lies above it.
By their numbers in this assay, from the lowest: compound 3; then compound 1; then compound 2.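

In this assay, the change from allyloxycarbonyl to ethoxycarbonyl, with the sulfur chain kept the same, gives a 4.3-fold lower number from compound 2 to compound 3 (0.63 log units; beyond the scatter) and so moves the number clearly beyond the scatter. The step of a 2.1-fold lower number from compound 1 to compound 3 (0.32 log units; beyond the scatter) comes from vinyl in place of ethyl on a saturated chain carbon bound to a sulfur, so a change in either side chain shifts the number. Nothing measured here gives a reason for either step.

Going by these compounds, whether a longer chain on the ester oxygen would lower the number further remains open. So does the outcome of replacing the ester with a carboxylic acid or an amide.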